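This account rests on a few compounds, and the source may have more. Where it says the series, first, only, none or still open, it means among the compounds named here.

Measured compounds:
- compound 1 `CC(=O)c1cc(C(=O)N[C@H](C)Cn2ccc(-c3cc(F)c(C#N)c(Cl)c3)n2)n[nH]1`: "not determined" (no result reported)
- compound 2 `CC(Cn1ccc(-c2ccc(C#N)c(Cl)c2)n1)C(=O)Nc1cc[nH]n1`: > 30000 nM

The assay here is an ADME assay on PC-3 cells (Homo sapiens) for cytotoxicity, read by CCK-8 assay, with a stated time of 6 days; a higher number here means a weaker inhibitor, a lower number a stronger inhibitor. For compound 1 no result was reported, so it gives nothing to compare with. Compound 2 is known only as a limit: in this assay compound 2 reaches > 30000 nM, which is a limit of the assay rather than a number. The numbers shown thus contain no step between measured compounds; the only firm point is the limit of > 30000 nM in this assay, at which 1 of the 2 values shown sits.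

Compound 3 `CC(Cn1ccc(-c2ccc(C#N)c(Cl)c2)n1)C(=O)Nc1cccc(C(C)O)c1` differs from compound 2 in one place: 3-(1-hydroxyethyl)phenyl in place of 1H-pyrazol-3-yl on an amide-type nitrogen. For the measured compounds named here, with no measured step to lean on, the size and direction of this change cannot be read from the data. The expectation for the step from compound 2 to compound 3 in this assay is therefore a modest one, an at least 2.0-fold lower number from compound 2 to compound 3 (0.30 log units; that floor lies within the scatter), with a fair chance that only a limit is reported again. The estimate for compound 3 in this assay is 15000 nM, within the range from 3000 nM to 60000 nM.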

Compound 3, half-maximal inhibitory concentration: > 30000 nM
Compound 3: no number, only a limit (the forecaster's own chance of this, stated with the estimate: 50%); at least 2.0-fold (0.30 log units) between middle value and limit.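

In this assay compound 3 gives > 30000 nM, which is a limit of the assay and not a number. Compound 2 also stands only at a limit, so no step between compound 2 and compound 3 can be read: the limit of > 30000 nM in this assay, at which 2 of the 3 values shown sit.

The compounds shown leave open whether any group on the amide-type nitrogen would give an actual number in this assay.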